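Replacing One Aromatic Ring on Compound 3

The source may report more compounds than this note shows. Statements on the series, on what has been measured and on what is new or still open speak of the compounds shown alone.

Three compounds have been measured in a functional assay on HepG2 cells (Homo sapiens) for antiproliferative activity, read by MTT assay, with a stated time of 48 h; a lower number here means a stronger inhibitor, a higher number a weaker inhibitor:

Compound 1 `CCCCOc1ccc(C(=O)/C=C/c2c(/C=C/c3ccc(OC)cc3)cc(OC)cc2OC)cc1` gives 12.9 ug/mL.
Compound 2 `COc1ccc(/C=C/c2cc(OC)cc(OC)c2/C=C/C(=O)c2ccc(N)cc2)cc1` gives 7.5 ug/mL.
Compound 3 `CCCC(C)Oc1ccc(C(=O)/C=C/c2c(/C=C/c3ccc(OC)cc3)cc(OC)cc2OC)cc1` gives 11.1 ug/mL.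

Compound 3 sits among the others: the step of a 1.2-fold lower number from compound 1 to compound 3 (0.07 log units; within the scatter) and the step of a 1.5-fold higher number from compound 2 to compound 3 (0.17 log units; within the scatter) are both within the scatter, so the three numbers cannot be told apart with confidence.

Compound 4 `COc1ccc(/C=C/c2cc(OC)cc(OC)c2/C=C/C(=O)c2ccc(C)c(C)c2)cc1` is not yet measured. It differs from compound 3 by 3,4-dimethylphenyl in place of 4-(1-methylbutoxy)phenyl on a carbonyl carbon. The two measured steps that touch this ring, a 1.2-fold lower number from compound 1 to compound 3 (0.07 log units; within the scatter) and a 1.5-fold higher number from compound 2 to compound 3 (0.17 log units; within the scatter), stayed within the scatter, though neither exchanged the whole ring. Within the data shown here, no measured step therefore points to a shift beyond the scatter in this assay. Compound 4 is expected to give about 11 ug/mL, between 5 ug/mL and 25 ug/mL, an expected step of a 1.0-fold lower number from compound 3 to compound 4 (0.00 log units; within the scatter).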

Compound 4, half-maximal inhibitory concentration: 0.2 ug/mL
Beside the measured number, compound 4's estimate is 55-fold (1.74 log units) above it, outside the stated range (below it).
By their numbers in this assay, from the lowest: compound 4; then compounds 2, 3 and 1 (each within the scatter of the next).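

In this assay, among these compounds, the earlier steps among compounds 1, 2 and 3 stayed within the scatter, so this position seemed tolerant of change, but exchanging the whole ring on the carbonyl carbon gives a 56-fold lower number from compound 3 to compound 4 (1.74 log units; beyond the scatter), a 38-fold lower number from compound 2 to compound 4 (1.57 log units; beyond the scatter) and a 65-fold lower number from compound 1 to compound 4 (1.81 log units; beyond the scatter). The 3,4-dimethylphenyl ring thus sets compound 4 clearly apart from all three compounds, whichever of the other rings they carry. No evidence here accounts for this large gap. As far as these compounds go, whether one methyl alone, or two chlorine atoms in place of both methyls, would keep the number this low remains open.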